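A few compounds are considered here, and "the series" means these few. Any claim that something is new, unique, unknown or untested is made for them only; others in the source may bear on it.

Compound 2 `O=C(CSc1nnnn1-c1cccc2ccccc12)N/N=C/c1ccc(Cl)cc1` is the starting point of this step. In an ADME assay on MT4 cells (Homo sapiens) for cytotoxicity, read by MTT assay (a lower number here means that less compound is tolerated, a higher number that more compound is tolerated), compound 2 gives a limit of the assay, > 295000 nM. Compound 1 `O=C(CSc1nnnn1-c1cccc2ccccc12)N/N=C/c1cccs1` likewise gives a limit, > 316000 nM in this assay. Compound 3 `COc1ccc(/C=N/NC(=O)CSc2nnnn2-c2cccc3ccccc23)cc1` also ends at a limit, > 298000 nM in this assay. All three values thus sit at limits, and none of the three compounds stands apart from the others. Compound 4 `COc1cccc(/C=N/NC(=O)CSc2nnnn2-c2cccc3ccccc23)c1OC` differs from compound 2 by 2,3-dimethoxyphenyl in place of 4-chlorophenyl on a carbon with a double bond to nitrogen. The measured steps that bear on this change are a step that the two limits leave unreadable from compound 1 to compound 2, a step that the two limits leave unreadable from compound 1 to compound 3 and a step that the two limits leave unreadable from compound 2 to compound 3, and each of them is left unreadable by the limits on both sides, so the exchange of chloro for methoxy gave no readable shift. With no readable step on record, no step beyond the scatter is expected in this assay, and the estimated step is a step that the limit leaves unreadable from compound 2 to compound 4. Compound 4 is therefore expected to give 300000 nM, within 150000 nM to 600000 nM, most likely once more as a limit.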

Compound 4, half-maximal cytotoxic concentration: 192000 nM
Compound 4: middle estimate off by 1.6-fold (0.19 log units), on the high side; measured number inside the range.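

In this assay compound 4 is the only one of the four compounds shown to give a number rather than a limit, so the 2,3-dimethoxyphenyl group at this carbon with a double bond to nitrogen brings the series within the readable range of the assay. Against the earlier compounds the change reads as an at least 1.5-fold lower number from compound 2 to compound 4 (0.18 log units; that floor lies within the scatter), an at least 1.5-fold lower number from compound 3 to compound 4 (0.19 log units; that floor lies within the scatter) and an at least 1.6-fold lower number from compound 1 to compound 4 (0.21 log units; that floor lies within the scatter). Each of these sizes is only a floor, and for compound 2 the starting point is a limit: the limit of > 295000 nM in this assay, at which 1 of the 4 values shown sits.

From the compounds shown here alone, whether the true steps go beyond the scatter stays open, as does whether the number of compound 4 depends on both methoxy groups or on one of them. The compounds shown also leave open how an amine or a carboxylic acid on this aromatic ring would read in this assay.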